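A Cyano Group Gives Way to 1-Hydroxyethyl

The source may hold more compounds than are shown below. What is called first, only, known or untested is meant among the compounds shown, and "the series" means these compounds.

Compound 1 `CNc1nc(NCc2ccc(NC(=O)c3ccc(F)cc3)cc2)c2cc(C)ccc2n1` and compound 2 `CN(C)c1nc(NCc2ccc(NC(=O)c3ccc(F)cc3)cc2)c2ccc(C#N)cc2n1` have both been tested in an in vitro ADME assay on microsomes from liver (Rattus norvegicus) for metabolic stability; on this read-out lower numbers stand for a shorter-lived compound and higher numbers for a longer-lived compound. Here compound 1 gives 0.1 h and compound 2 gives 0.183 h, two numbers that lie within the usual scatter of each other and so cannot be told apart. Compound 3 `CC(O)c1ccc2c(NCc3ccc(NC(=O)c4ccc(F)cc4)cc3)nc(N(C)C)nc2c1` is compound 2 altered in one place: 1-hydroxyethyl in place of cyano on an aromatic carbon. In short, 1-hydroxyethyl stands in place of cyano on an aromatic carbon. For the measured compounds named here, the two measured compounds differ from each other in more than one place, so no measured step shows what this swap does in this assay. With no direction to go on, the expected change is small and stays within the scatter: a 1.2-fold lower number from compound 2 to compound 3 (0.09 log units; within the scatter). For compound 3 the estimated half-life is 0.15 h, with an expected range from 0.07 h to 0.35 h.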

Compound 3, half-life: 0.1 h
Compound 3: the middle estimate sits 1.5-fold (0.18 log units) above what was measured; the range from low to high includes it.
By their numbers in this assay, from the lowest: compounds 1, 3 and 2 (each within the scatter of the next).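

In this assay the swap of cyano for 1-hydroxyethyl on this aromatic carbon now has a direct reading, which the earlier pair could not give: a 1.8-fold lower number from compound 2 to compound 3 (0.26 log units; within the scatter). The two groups therefore cannot be told apart on this read-out, even though 1-hydroxyethyl brings a hydrogen-bond donor that cyano lacks. No information at hand explains why the half-life stays within the scatter.

Going by these compounds, whether another group at this aromatic carbon, such as an amine or a carboxylic acid, would move the half-life beyond the scatter remains open. On these data alone, it is also open whether 1-hydroxyethyl would behave the same way in the setting of compound 1, which differs from compound 2 in more than one place.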